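Dimethoxyphenyl back on the ring nitrogen of compound 3

A few compounds are considered here, and "the series" means these few. Any claim that something is new, unique, unknown or untested is made for them only; others in the source may bear on it.

Compound 3 `O=C(NCCCCc1ccccc1)c1cccc(C2SCC(=O)N2c2ccccc2)c1` stands highest of the three compounds measured in a functional assay on 143B cells (Homo sapiens) for inhibition, read by CCK-8 assay, with a stated time of 72 h, tested at 1 uM; on this read-out lower numbers stand for less inhibition and higher numbers for more inhibition at the one concentration tested (going by the name of the read-out): compound 3 gives 60%. Its nearest neighbour is compound 2 `CCN1C(=O)CSC1c1cccc(C(=O)NCCCCc2ccccc2)c1`, which gives 40%, so that a number 20 percentage points higher from compound 2 to compound 3 (beyond the scatter). Furthest away is compound 1 `COc1ccc(OC)c(N2C(=O)CSC2c2cccc(C(=O)NCCCCc3ccccc3)c2)c1`, which gives 2%, and a number 58 percentage points higher from compound 1 to compound 3 (beyond the scatter).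

Compound 4 `COc1ccc(N2C(=O)CSC2c2cccc(C(=O)NCCCCc3ccccc3)c2)c(OC)c1` differs from compound 3 in one place: 2,4-dimethoxyphenyl in place of phenyl on an amide-type nitrogen in a ring. Among the measured compounds shown here, two measured steps bear on this change. The step of a number 58 percentage points higher from compound 1 to compound 3 (beyond the scatter) is the mirror of the present one, a dimethoxyphenyl set against a plain phenyl on the same amide-type nitrogen, though compound 1 carries 2,5-dimethoxyphenyl while compound 4 carries 2,4-dimethoxyphenyl. The step of a number 38 percentage points higher from compound 1 to compound 2 (beyond the scatter) shows the same dimethoxyphenyl compound far below the ethyl compound as well. For the measured compounds named here, both steps were large and both ran against the dimethoxyphenyl compound, so a large fall in this assay is expected for compound 4, tempered only by the different methoxy pattern, which no measured compound covers. Compound 4 is therefore estimated at 15%, within 0% to 45%, a step expected as a number 45 percentage points lower from compound 3 to compound 4 (beyond the scatter).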

Compound 4, a percentage reported as inhibition, at one concentration (the size of the read-out at that concentration, not a potency): 53%
Beside the measured number, compound 4's estimate is 38 percentage points below it, and the stated range ends below it.
By their numbers in this assay, from the lowest: compound 1; then compound 2; then compounds 4 and 3 (each within the scatter of the next).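

In this assay, a dimethoxyphenyl group on the amide-type nitrogen does not by itself bring the read-out down: 2,4-dimethoxyphenyl in place of phenyl gives a number 7 percentage points lower from compound 3 to compound 4 (within the scatter). What separates the dimethoxyphenyl compounds is the placing of their methoxy groups, as 2,4-dimethoxyphenyl in place of 2,5-dimethoxyphenyl gives a number 51 percentage points higher from compound 1 to compound 4 (beyond the scatter), so the large falls seen earlier belong to the 2,5-dimethoxyphenyl group and cannot be extended to dimethoxyphenyl groups in general. Set against ethyl, 2,4-dimethoxyphenyl gives a number 13 percentage points higher from compound 2 to compound 4 (beyond the scatter), so compound 4 joins compound 3 above compound 2 at this position, while compound 1 goes against any rule that an aromatic ring here outdoes ethyl. Nothing at hand explains why the two methoxy patterns part so widely.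

Still open, as far as these compounds go, is whether the 2-methoxyphenyl or the 5-methoxy pattern alone, as in 3-methoxyphenyl, would read like compound 1 or like compound 4. From the compounds shown here alone, it is also open how a larger change on this ring, such as a carboxylic acid or an amine in place of a methoxy group, would read, and what potency lies behind these single-concentration numbers.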